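A few compounds are considered here, and "the series" means these few. Any claim that something is new, unique, unknown or untested is made for them only; others in the source may bear on it.

Three compounds have been measured in a functional assay on the whole organism for activation, with Mus musculus as the target; on this read-out higher numbers stand for an effect only at larger amounts of compound and lower numbers for an effect already at smaller amounts:

Compound 1, `Nc1nc(O)nc2c1nc(O)n2Cc1ccccc1`, gives 1 mg/kg.
Compound 2, `Nc1nc(SCc2ccccc2)nc2c1nc(O)n2Cc1ccccc1`, gives only a limit of the assay, > 1 mg/kg.
Compound 3, `CCOc1nc(N)c2nc(O)n(Cc3ccccc3)c2n1`, gives 0.3 mg/kg.

Among the measured compounds shown here, compound 3 stands lowest of the two numbers: compound 1 sits at a 3.3-fold lower number from compound 1 to compound 3 (0.52 log units; beyond the scatter) from it, the only other value being the limit of compound 2 (the limit of > 1 mg/kg in this assay, at which 1 of the 3 values shown sits).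

Compound 4, `CCCc1nc(N)c2nc(O)n(Cc3ccccc3)c2n1`, is the next compound. It differs from compound 3 as follows: propyl in place of ethoxy on an aromatic carbon. For the measured compounds named here, no measured step swaps these two groups directly. The steps that touch this position are a 3.3-fold lower number from compound 1 to compound 3 (0.52 log units; beyond the scatter) and an at least 3.3-fold lower number from compound 2 to compound 3 (0.52 log units; beyond the scatter), both ending at compound 3 and both favouring it. The change to compound 4 keeps the chain of three heavy atoms but removes the oxygen, so a number close to that of compound 3 is expected, with a shift of a 1.7-fold higher number from compound 3 to compound 4 (0.22 log units; within the scatter). Compound 4 is therefore estimated at 0.5 mg/kg, with a range from 0.15 mg/kg to 1.5 mg/kg.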

Compound 4, minimum effective dose: 3 mg/kg
Compound 4: middle estimate off by 6.0-fold (0.78 log units), on the low side; measured number outside the range, above it.
By their numbers in this assay, from the lowest: compound 3; then compound 1; then compound 4.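

In this assay, ethoxy and propyl both have 3 heavy atoms and neither has a ring, yet replacing ethoxy with propyl gives a 10-fold higher number from compound 3 to compound 4 (1.00 log units; beyond the scatter) and so the size of the chain alone does not set the number at this position. Propyl also ends up behind the hydroxy group, with a 3.0-fold higher number from compound 1 to compound 4 (0.48 log units; beyond the scatter) on the same aromatic carbon, so a carbon chain here does not improve on hydroxy the way ethoxy does. Compound 2 gives only a limit, so its step to compound 4 cannot be read: the limit of > 1 mg/kg in this assay, at which 1 of the 4 values shown sits.

From the compounds shown here alone, whether the oxygen itself accounts for the gap remains open, as does whether a methoxy, propoxy or butyl group on this carbon would follow ethoxy or propyl. Going by these compounds, how an amine attached here through its nitrogen would compare is also open.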